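Trifluoromethyl in place of iodo on a weakly active core

This account rests on a few compounds, and the source may have more. Where it says the series, first, only, none or still open, it means among the compounds named here.

Compound 1 `O=c1[nH]c(=O)n([C@H]2C[C@@H]3O[PH](O)(O)OC[C@H]3O2)cc1Br` gives 457 ug/mL in a functional assay on L1210 cells (Mus musculus) for antiproliferative activity; on this read-out lower numbers stand for stronger inhibition and higher numbers for weaker inhibition. Compound 2 `O=c1[nH]c(=O)n([C@H]2C[C@@H]3O[PH](O)(O)OC[C@H]3O2)cc1I` reaches only the limit of >= 500 ug/mL in this assay, so its number is not known exactly (the limit of >= 500 ug/mL in this assay, at which 1 of the 2 values shown sits). The step of an at least 1.0-fold higher number from compound 1 to compound 2 (0.03 log units; that floor lies within the scatter) is the only measured one and lies within the scatter. Compound 3 `O=c1[nH]c(=O)n([C@H]2C[C@@H]3O[PH](O)(O)OC[C@H]3O2)cc1C(F)(F)F` differs from compound 2 by trifluoromethyl in place of iodo on an aromatic carbon. With one measured step that shows no change beyond the scatter, no shift is expected; compound 3 is estimated at 450 ug/mL, within 200 ug/mL to 500 ug/mL. The step of an at least 1.1-fold lower number from compound 2 to compound 3 (0.04 log units; that floor lies within the scatter) expected for this change is therefore small.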

Compound 3, concentration for 50% inhibition: 0.116 ug/mL
Compound 3: middle estimate off by 3900-fold (3.59 log units), on the high side; the whole stated range lies above it.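

In this assay this aromatic carbon proves highly sensitive to the group it carries. Bromo and iodo lie within the scatter of each other, yet trifluoromethyl brings a 3900-fold lower number from compound 1 to compound 3 (3.60 log units; beyond the scatter) and an at least 4300-fold lower number from compound 2 to compound 3 (3.63 log units; beyond the scatter) on the same core. The second step is only a floor, as compound 2 stands at a limit of the assay: the limit of >= 500 ug/mL in this assay, at which 1 of the 3 values shown sits.

The compounds shown leave open why trifluoromethyl differs so sharply from the two halogens. They also leave open whether methyl or a nitrile on this carbon would follow trifluoromethyl or the halogens.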